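The source may hold more compounds than are shown below. What is called first, only, known or untested is meant among the compounds shown, and "the series" means these compounds.

Measured so far:
- compound 1 `COc1ccccc1C1CC(c2cc3ccccc3o2)=NN1C(=O)c1ccncc1`: > 202000 nM
- compound 2 `CCn1cc(C(=O)N2N=C(c3cc4ccccc4o3)CC2c2ccccc2O)c(=O)c2ccc(C)nc21`: > 157000 nM

Both readings come from an ADME assay on Vero cells (Chlorocebus sabaeus) for cytotoxicity, read by MTT assay, with a stated time of 72 h (on this read-out higher numbers stand for weaker inhibition and lower numbers for stronger inhibition), and neither is a number. The value for compound 1 is a limit of the assay. Compound 2 likewise stands only at a limit, > 157000 nM.

Compound 3 `CCn1cc(C(=O)N2N=C(c3cc4ccccc4o3)CC2c2ccc(OC)cc2O)c(=O)c2ccc(C)nc21` replaces the 2-hydroxyphenyl of compound 2 with 2-hydroxy-4-methoxyphenyl: methoxy in place of hydrogen on an aromatic carbon. Among the measured compounds shown here, no step between measured compounds is available to size this change. With compound 2 at > 157000 nM, no step beyond the scatter is expected in this assay, in either direction, and a further limit is the most likely report. The estimated change, an at least 1.0-fold lower number from compound 2 to compound 3 (0.03 log units; that floor lies within the scatter), is therefore treated as no real shift. For compound 3 the expected value is 145000 nM, with an estimated range of 70000 nM to 260000 nM.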

Compound 3, half-maximal inhibitory concentration: > 154000 nM
Compound 3: only a limit was reported (the forecaster's own chance of this, stated with the estimate: 80%); middle value at least 1.0-fold (0.02 log units) away from the limit.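

In this assay compound 2 gives > 157000 nM, a limit of the assay. Compound 3 gives > 154000 nM, also a limit, so no step can be read between compound 2 and compound 3. On these data alone, whether methoxy in place of hydrogen on an aromatic carbon changes the reading at all stays open.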